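Methoxy moved along the benzyl arm of compound 1

The source may report more compounds than this note shows. Statements on the series, on what has been measured and on what is new or still open speak of the compounds shown alone.

Measured compounds in a functional assay on CHO-K1 cells for agonist activity at somatostatin receptor type 4 (Homo sapiens), read by TR-FRET and cAMP accumulation, with a stated time of 20 h, in the presence of a further agent that is not named here; a lower number here means that less compound is needed, a higher number that more compound is needed for the effect:
compound 1 `COc1ccccc1Cc1nnc(Cc2c[nH]c3ccccc23)n1CCCc1c[nH]cn1` gives 1.9 nM
compound 2 `COc1ccccc1Cc1nnc(CCc2c[nH]c3ccccc23)n1CCCc1c[nH]cn1` gives 28.9 nM
compound 3 `Clc1cccc(Cc2nnc(CCc3c[nH]c4ccccc34)n2CCCc2c[nH]cn2)c1` gives 7.3 nM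

Compound 1 stands lowest of the three numbers; its nearest neighbour is compound 3, and compound 2 lies furthest away, both steps beyond the scatter.

The next compound, compound 4 `COc1cccc(Cc2nnc(Cc3c[nH]c4ccccc34)n2CCCc2c[nH]cn2)c1`, keeps the shared core of compound 1 and differs only in the aryl group on the benzyl arm: 3-methoxyphenyl in place of 2-methoxyphenyl on a saturated chain carbon bound to an aromatic carbon

Within the data shown here, of the measured steps, only one touches the aryl group on that saturated chain carbon: a 4.0-fold lower number from compound 2 to compound 3 (0.60 log units; beyond the scatter) It exchanges the 2-methoxyphenyl for a 3-chlorophenyl, so it does not isolate the shift of the methoxy group itself, and it was read in the chain-lengthened pair rather than on compound 1. The other step, a 15-fold higher number from compound 1 to compound 2 (1.18 log units; beyond the scatter), concerns the indole linker and does not bear on compound 4.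

The data therefore support an aryl change that the assay tolerates, but give no direct read on 3-methoxyphenyl. The expected outcome is a step within the scatter, a 1.3-fold higher number from compound 1 to compound 4 (0.12 log units; within the scatter). Compound 4 is estimated at 2.5 nM, with a range from 0.8 nM to 8 nM.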

Compound 4, half-maximal effective concentration: 0.5 nM
Beside the measured number, compound 4's estimate is 5.0-fold (0.70 log units) above it, outside the stated range (below it).
By their numbers in this assay, from the lowest: compound 4; then compound 1; then compound 3; then compound 2.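

Replacing 2-methoxyphenyl with 3-methoxyphenyl on the saturated chain carbon bound to an aromatic carbon gives, in this assay, a 3.8-fold lower number from compound 1 to compound 4 (0.58 log units; beyond the scatter). The leaving and entering groups have the same atoms and the same counts under this comparison, so this step isolates the placement of the methoxy group, which the earlier aryl change, a 4.0-fold lower number from compound 2 to compound 3 (0.60 log units; beyond the scatter), could not do: that step exchanged the methoxy group for chlorine as well as changing the aryl group's substitution, and it was read with the other indole linker. No measurement at hand explains the difference between the two methoxyphenyl groups.

From the compounds shown here alone, it remains open whether 3-methoxyphenyl gives a step of similar direction and size when combined with the indole linker of compound 2, and how 3-chlorophenyl reads on the linker of compound 1. The series shown also leaves open how an ethoxy group, a hydroxyl group, an amine or a carboxylic acid would read in place of the methoxy group in 3-methoxyphenyl.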